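Benzamide Thiourea Series: Cytotoxicity Notes and One Open Position

The source may report more compounds than this note shows. Statements on the series, on what has been measured and on what is new or still open speak of the compounds shown alone.

Measured compounds:
compound 1 `Nc1ccccc1NC(=O)c1ccc(NC(=S)NCc2cncc(Br)c2)cc1`: 9200 nM
compound 2 `Nc1ccccc1NC(=O)c1ccc(NC(=O)NCc2ccc(Cl)nc2)cc1`: 5200 nM
compound 3 `Nc1ccccc1NC(=O)c1ccc(CNC(=O)c2cc3cccnc3[nH]2)cc1`: 10000 nM

All three share the same core and were read in a functional assay on HCT-116 cells (Homo sapiens) for cytotoxicity, read by MTT assay, with a stated time of 72 h; on this read-out lower numbers stand for stronger inhibition and higher numbers for weaker inhibition. The numbers sit close together. Compound 1 gives 9200 nM, which is the second highest of the three values; its nearest neighbour is compound 3 and its furthest is compound 2, and both of those gaps are within the scatter. Among the compounds with values here, no pair in this set differs by more than the scatter, so no order among the three can be drawn from these numbers.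

Compound 4 `Nc1ccccc1NC(=O)c1ccc(NC(=S)NCc2cccc(F)c2)cc1` has not yet been measured in this assay. Relative to compound 1 the change is 3-fluorophenyl in place of 5-bromopyridin-3-yl on a saturated chain carbon bound to an amide-type nitrogen. Within the data shown here, no measured pair in this set isolates such a change, so the only guide is the tight cluster of the three values and the fact that compound 1 differs from compounds 2 and 3 only within the scatter.

On that basis the step from compound 1 to compound 4 is expected to be small, with no direction beyond the scatter: a 1.2-fold lower number from compound 1 to compound 4 (0.06 log units; within the scatter). Compound 4 is estimated at 8000 nM in this assay, with a range from 3000 nM to 20000 nM.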

Compound 4, half-maximal inhibitory concentration: 5900 nM
The estimate for compound 4 lay 1.4-fold (0.13 log units) above the measured number; measured number inside the range.
By their numbers in this assay, from the lowest: compounds 2, 4, 1 and 3 (each within the scatter of the next).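

In this assay, within the data shown here, the exchange of 5-bromopyridin-3-yl for 3-fluorophenyl on a saturated chain carbon bound to an amide-type nitrogen gives the first single-place comparison, and it reads as a 1.6-fold lower number from compound 1 to compound 4 (0.19 log units; within the scatter), so no direction can be assigned to the change. At this position, a ring of carbon only with fluorine thus gives a number that cannot be told apart from that of a ring with one hetero atom and bromine, at the same count of heavy atoms and with the one hydrogen-bond acceptor of 5-bromopyridin-3-yl gone. Nothing available bears on the cause of this result, and the ring nitrogen and the halogen change together in this one step, so their separate contributions cannot be read.

Still open, on these data alone, is whether any group at this position can move the number beyond the scatter, for example a phenyl ring carrying a carboxylic acid or a dimethylamino group, or a longer chain in place of the methyl linker. Among these compounds, also open is how the thiourea compares with a urea carrying the same group, since compounds 1, 2 and 4 offer no pair that differs in that one place.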